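The compounds below may be only part of what the source reports. "The series", "measured", "known", "first", "only" and "open" are said of these compounds alone.

Measured so far in a functional assay on CWR22R cells (Homo sapiens) for inhibition, read by MTT assay, with a stated time of 48 h; a higher number here means a weaker inhibitor, a lower number a stronger inhibitor:

compound 1 `Clc1ccc(Cn2cc(C3CC(c4ccncc4)=NO3)c3ccccc32)cc1`: 9600 nM
compound 2 `COc1ccc2c(c1)c(C1CC(c3ccncc3)=NO1)cn2Cc1ccc(Cl)cc1`: 10600 nM
compound 3 `c1ccc2c(C3CC(c4ccncc4)=NO3)c[nH]c2c1`: a limit of this assay, > 100000 nM, not a number

Compound 2 differs from compound 1 by methoxy in place of hydrogen on an aromatic carbon. That change made a 1.1-fold higher number from compound 1 to compound 2 (0.04 log units; within the scatter). The cores of compound 1 and compound 3 differ by hydrogen in place of 4-chlorobenzyl on an aromatic nitrogen, and that step is an at least 10-fold higher number from compound 1 to compound 3 (1.01 log units; beyond the scatter). For compound 3 only a limit is known, as the limit of > 100000 nM in this assay, at which 1 of the 3 values shown sits, shows.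

Compound 4 `COc1ccc2[nH]cc(C3CC(c4ccncc4)=NO3)c2c1` is not yet measured in this assay. It differs from compound 3 by methoxy in place of hydrogen on an aromatic carbon. Within the data shown here, this is the same change as the one between compound 1 and compound 2: the group that leaves, the group that enters and the place agree word for word. The earlier instance gave a 1.1-fold higher number from compound 1 to compound 2 (0.04 log units; within the scatter), a step within the scatter. On the strength of that single precedent the new step is expected to be small as well: a step that the limit leaves unreadable from compound 3 to compound 4. Because the limit of > 100000 nM in this assay, at which 1 of the 3 values shown sits, already holds for compound 3, the most likely outcome is that compound 4 also returns only a limit rather than a number. Compound 4 is accordingly expected to give 150000 nM, with a range from 60000 nM to 400000 nM. Among the measured compounds shown here, whether a methoxy group changes anything at all on the core of compound 3 rests on compound 1 and compound 2 alone; no other pair here tests it.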

Compound 4, half-maximal inhibitory concentration: 35500 nM
Beside the measured number, compound 4's estimate is 4.2-fold (0.63 log units) above it; the whole stated range lies above it.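

In this assay, methoxy in place of hydrogen on an aromatic carbon gives an at least 2.8-fold lower number from compound 3 to compound 4 (0.44 log units; beyond the scatter), so the step seen on the core of compound 1 does not carry over to the core of compound 3: the same change on two cores in this assay, a 1.1-fold higher number (0.04 log units; within the scatter) from compound 1 to compound 2 and an at least 2.8-fold lower number (0.44 log units; beyond the scatter) from compound 3 to compound 4, at least 3.1-fold (0.49 log units) apart, beyond the scatter of two such steps

Hydrogen in place of 4-chlorobenzyl on an aromatic nitrogen, taken with the methoxy group present, gives a 3.3-fold higher number from compound 2 to compound 4 (0.52 log units; beyond the scatter), and this step also depends on the core that carries it: the same change on two cores in this assay, an at least 10-fold higher number (1.01 log units; beyond the scatter) from compound 1 to compound 3 and a 3.3-fold higher number (0.52 log units; beyond the scatter) from compound 2 to compound 4, at least 3.1-fold (0.49 log units) apart, beyond the scatter of two such steps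

From the compounds shown here alone, compound 3 sits at a limit of the assay, > 100000 nM, not a number, so the true size of both gaps stays unknown, and two cores alone do not show how either change would behave on a further core.

Open, going by these compounds, is whether the dependence on the core belongs to methoxy alone, or whether another group on the same aromatic carbon, such as fluoro, hydroxy or an amine, would also give different steps with and without 4-chlorobenzyl. Also open, on these data alone, is what a simple methyl or an unsubstituted benzyl on the aromatic nitrogen would give, with and without methoxy, in this assay.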